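Shortening the amine chain on a second core

This account rests on a few compounds, and the source may have more. Where it says the series, first, only, none or still open, it means among the compounds named here.

Compound 1 `CN(C)CCCNc1nc(-c2ccc(NC(=O)Nc3ccccc3F)cc2)nc2ccsc12` and compound 3 `CN(C)CCNc1nc(-c2ccc(NC(=O)Nc3ccccc3F)cc2)nc2ccsc12` share one core and differ only in the amine-bearing side chain. In a functional assay on MKN-45 cells (Homo sapiens) for cytotoxicity, read by MTT assay, with a stated time of 72 h (a higher number here means a weaker inhibitor, a lower number a stronger inhibitor), compound 1 gives 730 nM, and compound 3 gives 530 nM. The change between them is dimethylamino in place of (dimethylamino)methyl on a saturated chain carbon, two bonds along the chain from a nitrogen on an aromatic ring; it made a 1.4-fold lower number from compound 1 to compound 3 (0.14 log units; within the scatter).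

Compound 2 `CN(C)CCCNc1nc(-c2ccc(NC(=O)Nc3ccc(F)cc3)cc2)nc2c(Cl)c(Cl)sc12` carries a different core, and the difference between the two cores is not broken down here. In this assay compound 2 gives 1120 nM. Compound 4 `CN(C)CCNc1nc(-c2ccc(NC(=O)Nc3ccc(F)cc3)cc2)nc2c(Cl)c(Cl)sc12` is related to compound 2 by the same change, (dimethylamino in place of (dimethylamino)methyl on a saturated chain carbon, two bonds along the chain from a nitrogen on an aromatic ring), and has not yet been measured in this assay.

Because the first occurrence of this change gave a 1.4-fold lower number from compound 1 to compound 3 (0.14 log units; within the scatter), a step of similar size is expected here, a 1.4-fold lower number from compound 2 to compound 4 (0.15 log units; within the scatter), although one earlier example is a thin basis and that step itself lay within the scatter. Compound 4 is therefore estimated at 800 nM in this assay, with a likely range from 400 nM to 1600 nM.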

Compound 4, half-maximal inhibitory concentration: 1350 nM
Beside the measured number, compound 4's estimate is 1.7-fold (0.23 log units) below it; the range from low to high includes it.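

Replacing (3-(dimethylamino)propyl)amino with (2-(dimethylamino)ethyl)amino on the core of compound 2 gives a 1.2-fold higher number from compound 2 to compound 4 (0.08 log units; within the scatter) in this assay. Set beside the same replacement on the core of compound 1, the two steps cannot be told apart: the same change on two cores in this assay, a 1.4-fold lower number (0.14 log units; within the scatter) from compound 1 to compound 3 and a 1.2-fold higher number (0.08 log units; within the scatter) from compound 2 to compound 4, 1.7-fold (0.22 log units) apart, within the scatter of two such steps This shows that in these two pairs the shorter chain leaves the number within the scatter on both cores, so the change can be carried from one core to the other without a measurable difference; it does not show that the change has a fixed size or direction, as both steps are too small to read and two pairs are a narrow basis.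

The compounds shown leave open what a longer chain, or a primary amine or carboxylic acid in place of the dimethylamino group, would do in this assay. Going by these compounds, whether the same replacement stays this small on further cores also remains open.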